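This account rests on a few compounds, and the source may have more. Where it says the series, first, only, none or still open, it means among the compounds named here.

Measured so far:
- compound 1, `O=C(Nc1cccc(-n2cc(-c3ccncc3)c(-c3cc(O)cc(Cl)c3)n2)c1)Nc1ccc(Cl)c(C(F)(F)F)c1`: 104%
- compound 2, `O=C(Nc1cccc(-n2cc(-c3ccncc3)c(-c3cc(O)cc(Cl)c3)n2)c1)Nc1ccc(Cl)c(Cl)c1`: 91%

In a functional assay on ACHN cells (Homo sapiens) for inhibition, read by sulforhodamine B assay, with a stated time of 48 h, tested at 0.01 uM (a higher number here means a weaker effect of the compound at the concentration tested, a lower number a stronger effect), compound 1 gives 104%, the highest of the two numbers shown; the nearest is compound 2, reached by the step of a number 13 percentage points lower from compound 1 to compound 2 (beyond the scatter). The pair thus spans a modest spread, both values sitting near no inhibition at the concentration tested.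

Compound 3, `COc1cc(Cl)cc(-c2nn(-c3cccc(NC(=O)Nc4ccc(Cl)c(C(F)(F)F)c4)c3)cc2-c2ccncc2)c1`, is not yet measured. It differs from compound 1 by methyl in place of hydrogen on an oxygen on an aromatic ring, on the 3-chloro-5-hydroxyphenyl ring, giving hydroxy to methoxy. Going by the values given here, no measured step touches this oxygen; the one step known, from chloro to trifluoromethyl on the other aryl urea ring, is a different change and bears on it only as a measure of how little the whole series moves in this assay. Among the compounds with values here, with no bearing step, the expected step is a number 4 percentage points lower from compound 1 to compound 3 (within the scatter), that is, none beyond the scatter. Compound 3 is therefore estimated at 100%, within 85% to 115%.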

Compound 3, a percentage reported as activity, at one concentration (the size of the read-out at that concentration, not a potency): 91%
For compound 3 the middle estimate is 9 percentage points above the measured one, and the stated range covers the measured number.
By their numbers in this assay, from the lowest: compounds 2 and 3 (each within the scatter of the next); then compound 1.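

In this assay, going by these compounds alone, methyl in place of hydrogen on the oxygen of the 3-chloro-5-hydroxyphenyl ring gives a number 13 percentage points lower from compound 1 to compound 3 (beyond the scatter), the first reading at this position. The read-out therefore responds to a change at this oxygen as well as to the change on the other aryl urea ring, and the direction from hydroxy to methoxy is toward a stronger effect, though the step is modest. Nothing available accounts for this shift.

Still open, from the compounds shown here alone, is whether an ethoxy group or a longer chain on this oxygen, or an amine or a carboxylic acid in place of the hydroxy, would move the number further. Also open is whether methoxy and chloro in place of trifluoromethyl would add up in one compound, and how any of these compounds would read at higher concentrations.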